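Methyl on the Bridging Nitrogen of Compound 1

The source may hold more compounds than are shown below. What is called first, only, known or untested is meant among the compounds shown, and "the series" means these compounds.

Compound 1 `c1cc2c(cc1NC1=NCCN1)OCCO2` gives 2400 nM in an assay on Cerebral cortex for binding affinity to Adrenergic receptor alpha-1 (Homo sapiens) (on this read-out higher numbers stand for weaker inhibition and lower numbers for stronger inhibition), the highest of the three numbers at hand. Compound 3 `COc1ccc(NC2=NCCN2)c(C)c1OC` gives 1500 nM, which lies within the scatter of compound 1, and compound 2 `Cc1c(NC2=NCCN2)ccc2c1OCCO2` gives 130 nM. Going by the values given here, the only single-point step among them, an 18-fold lower number from compound 1 to compound 2 (1.27 log units; beyond the scatter), concerns methyl in place of hydrogen on an aromatic carbon. Compound 4 `CN(C1=NCCN1)c1ccc2c(c1)OCCO2` differs from compound 1 by methyl in place of hydrogen on a nitrogen on an aromatic ring. Among the compounds with values here, no measured step touches this nitrogen, so that large aromatic step gives no direct guide, and for compound 4 only a modest step toward a higher number, a 2.1-fold higher number from compound 1 to compound 4 (0.32 log units; beyond the scatter), is expected. Compound 4 is therefore estimated at 5000 nM, with a range from 1500 nM to 16000 nM.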

Compound 4, inhibition constant: 30000 nM
Beside the measured number, compound 4's estimate is 6.0-fold (0.78 log units) below it; measured number above the stated range.
By their numbers in this assay, from the lowest: compound 2; then compounds 3 and 1 (each within the scatter of the next); then compound 4.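

Placing methyl instead of hydrogen on this nitrogen on an aromatic ring gives, in this assay, a 13-fold higher number from compound 1 to compound 4 (1.10 log units; beyond the scatter), so a single added carbon at this position has a large effect on the number. The same group on an aromatic carbon gave an 18-fold lower number from compound 1 to compound 2 (1.27 log units; beyond the scatter), so in this pair of steps, the direction depends on where methyl stands. Nothing at hand bears on why these steps differ.

Going by these compounds, whether ethyl or a longer chain on this nitrogen would follow methyl stays open. So does whether an acetyl group there would give a comparable number.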